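Removing the methyl from the meta ether: cytotoxicity outlook

The compounds below may be only part of what the source reports. "The series", "measured", "known", "first", "only" and "open" are said of these compounds alone.

Measured so far in an ADME assay on Vero cells (Chlorocebus sabaeus) for cytotoxicity; on this read-out lower numbers stand for higher toxicity in this test and higher numbers for lower toxicity in this test:
- compound 1, `C=CCOc1ccc(-c2nc3c(NC4CCCC4)cccn3c2-c2ccnc(NC3CCCC3)n2)cc1`: > 40000 nM
- compound 2, `c1cc(NC2CCCC2)c2nc(-c3ccc(OCC4CC4)cc3)c(-c3ccnc(NC4CCCC4)n3)n2c1`: > 40000 nM
- compound 3, `COc1cccc(-c2nc3c(NC4CCCC4)cccn3c2-c2ccnc(NC3CCCC3)n2)c1`: > 40000 nM

Compound 3 stands only at a limit of this assay, > 40000 nM, not at a number. Compound 1 is likewise reported only as the limit > 40000 nM. Compound 2 too gives only the limit > 40000 nM. All three therefore share (the limit of > 40000 nM in this assay, at which 3 of the 3 values shown sit), and none of the changes between them can be sized: a step that the two limits leave unreadable from compound 1 to compound 2, a step that the two limits leave unreadable from compound 1 to compound 3 and a step that the two limits leave unreadable from compound 2 to compound 3 are each hidden by the two limits. Among the measured compounds shown here, the series so far shows no cytotoxicity that this assay can resolve, and it gives no readable step for any change at the aryl ether position.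

The next compound, compound 4, `Oc1cccc(-c2nc3c(NC4CCCC4)cccn3c2-c2ccnc(NC3CCCC3)n2)c1`, differs from compound 3 by hydrogen in place of methyl on an oxygen on an aromatic ring. For the measured compounds named here, no measured step in this set speaks to the size of such a change, so the expectation rests on the three limits alone. Compound 4 is expected to remain at or near the same limit, with an estimated value of 45000 nM and a range from 20000 nM to 100000 nM. The corresponding step from compound 3 is thus estimated as a step that the limit leaves unreadable from compound 3 to compound 4, with a strong chance that only a limit is reported again.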

Compound 4, half-maximal cytotoxic concentration: > 40000 nM
Compound 4: a limit, no number; the forecaster's own chance of this, stated with the estimate: 75%; the middle value is on the limit's open side.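

Compound 4 is reported only as a limit, > 40000 nM, so no step from compound 1, compound 2 or compound 3 to compound 4 can be read in this assay: the limit of > 40000 nM in this assay, at which 4 of the 4 values shown sit.

The compounds shown leave open what numerical cytotoxic concentration any of them has, and therefore how much methoxy to hydroxy changes it.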